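The compounds below may be only part of what the source reports. "The series", "measured", "known", "first", "only" and "open" are said of these compounds alone.

Working notes on the series.

The shared core of compound 1 `CCCS(=O)(=O)Nc1ccc(F)c(C(=O)c2n[nH]c3ncc(-c4ccccc4OC)cc23)c1F` carries a 2-methoxyphenyl, and in an assay for binding affinity to dual specificity mitogen-activated protein kinase kinase 4 (Homo sapiens), read by KINOMEscan, tested at 100 nM (on this read-out lower numbers stand for a stronger effect and higher numbers for a weaker effect at the one concentration tested), compound 1 gives 1.9%. Compound 2 `CCCS(=O)(=O)Nc1ccc(F)c(C(=O)c2n[nH]c3ncc(-c4ccc(OC)cc4)cc23)c1F` carries a 4-methoxyphenyl instead, and in this assay compound 2 gives 4.2%; the step of a number 2.3 percentage points higher from compound 1 to compound 2 (within the scatter) stays within the scatter. Compound 3 `CCCS(=O)(=O)Nc1ccc(F)c(C(=O)c2n[nH]c3ncc(-c4ccc(O)cc4)cc23)c1F` carries a 4-hydroxyphenyl, and in this assay compound 3 gives 0.75%. Compound 3 stands with both others within the scatter: a number 1.2 percentage points lower from compound 1 to compound 3 (within the scatter) and a number 3.5 percentage points lower from compound 2 to compound 3 (within the scatter) are both small, so the three numbers are not told apart.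

Compound 4 `CCCS(=O)(=O)Nc1ccc(F)c(C(=O)c2n[nH]c3ncc(-c4ccc(N(C)C)cc4)cc23)c1F` has not been measured. It differs from compound 3 by dimethylamino in place of hydroxy on an aromatic carbon.

The step that bears most directly on this change is a number 3.5 percentage points lower from compound 2 to compound 3 (within the scatter), which replaced the methyl on the oxygen at the same place and moved the number within the scatter; a number 1.2 percentage points lower from compound 1 to compound 3 (within the scatter) and a number 2.3 percentage points higher from compound 1 to compound 2 (within the scatter) show that shifting or altering the group on this phenyl has likewise not moved the number beyond the scatter. Going by the values given here, no measured step involves a dimethylamino, so the expectation rests on the three small steps alone. The expected step of a number 1.8 percentage points higher from compound 3 to compound 4 (within the scatter) is therefore none beyond the scatter. For compound 4 in this assay the estimate is 2.5%, with a range from 0.4% to 12%.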

Compound 4, a percentage reported as activity, at one concentration (the size of the read-out at that concentration, not a potency): 2.5%
Compound 4: the middle estimate sits on the measured number at the digits printed; low and high end bracket the measured number.
By their numbers in this assay, from the lowest: compounds 3, 1, 4 and 2 (each within the scatter of the next).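

In this assay the series now includes a nitrogen-bearing group on this phenyl as well as the oxygen-bearing ones: a number 1.8 percentage points higher from compound 3 to compound 4 (within the scatter) and a number 1.7 percentage points lower from compound 2 to compound 4 (within the scatter) and a number 0.6 percentage points higher from compound 1 to compound 4 (within the scatter) are all small steps. At this place, para to a large group, dimethylamino with 3 heavy atoms and 0 hydrogen-bond donors stands in for hydroxy with 1 heavy atom and 1 hydrogen-bond donor, and this change does not separate compound 4 from compound 3, so neither the larger size nor the missing donor shows up in the number at this one concentration. Nothing available explains why the number holds across these groups.

The compounds shown leave open whether a carboxylic acid or a longer chain at this place would carry the number beyond the scatter, and whether dimethylamino would behave the same at the place the methoxy holds in compound 1. From the compounds shown here alone, every compound here keeps the rest of the shared core unchanged, so the effect of a change elsewhere also remains open.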